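Aryl substituent exchange from compound 2 to compound 3

The source may report more compounds than this note shows. Statements on the series, on what has been measured and on what is new or still open speak of the compounds shown alone.

Compound 2 `C=C1C(=O)OC(C)CC1c1ccc(Br)cc1` gives 1750 nM in a functional assay on L1210 cells (Mus musculus) for cytotoxicity, read by MTT assay, with a stated time of 48 h; a higher number here means a weaker inhibitor, a lower number a stronger inhibitor. For the measured compounds named here, of the two numbers measured so far, compound 2 stands at the upper one, its only neighbour being compound 1 `C=C1C(=O)OC(C)CC1c1ccc([N+](=O)[O-])cc1`, which gives 1200 nM in this assay. Going by the values given here, the single step between them, a 1.5-fold higher number from compound 1 to compound 2 (0.16 log units; within the scatter), lies within the scatter, so the two compounds cannot be separated on these numbers.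

Compound 3 `C=C1C(=O)OC(C)CC1c1ccc(OC)cc1` has not yet been measured. It differs from compound 2 by methoxy in place of bromo on an aromatic carbon. Among the compounds with values here, no measured step exchanges bromo for methoxy; the one step that exists, a 1.5-fold higher number from compound 1 to compound 2 (0.16 log units; within the scatter), concerns nitro and bromo and did not move the number beyond the scatter. It bears on the present change only in showing that one exchange at this aromatic carbon left the number essentially unchanged, and it gives no direction for a methoxy group. The expected step of no change at the digits printed from compound 2 to compound 3 (within the scatter) is therefore none beyond the scatter. Compound 3 is estimated at 1750 nM in this assay, with a range from 700 nM to 4400 nM.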

Compound 3, half-maximal inhibitory concentration: 800 nM
Beside the measured number, compound 3's estimate is 2.2-fold (0.34 log units) above it; measured number inside the range.
By their numbers in this assay, from the lowest: compounds 3, 1 and 2 (each within the scatter of the next, the first and the last beyond it).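

In this assay this position now gives its first step beyond the scatter: a 2.2-fold lower number from compound 2 to compound 3 (0.34 log units; beyond the scatter), with methoxy in place of bromo on an aromatic carbon para to a group of 9 heavy atoms. The same methoxy group set against nitro gives a 1.5-fold lower number from compound 1 to compound 3 (0.18 log units; within the scatter), so compound 1 and compound 3 cannot be separated, and the exchanges at this carbon separate only compound 2 from compound 3 among the three compounds, which shows that the number can respond to the group here, though only modestly so far. Nothing measured alongside these numbers accounts for the step.

As far as these compounds go, whether the separation of compound 2 from compound 3 reflects methoxy or bromo remains open, as compound 1 lies within the scatter of both and so gives no ordering of the three groups on its own. From the compounds shown here alone, how an amine, a carboxylic acid or a longer alkoxy chain on this aromatic carbon would compare in this assay also remains open, as does whether any step here would grow beyond a modest size.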